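Swapping a Trifluoromethyl for Methoxy on Two Related Amides

The compounds below may be only part of what the source reports. "The series", "measured", "known", "first", "only" and "open" are said of these compounds alone.

Compound 1 `O=C(NCc1cn(Cc2ccc(C(F)(F)F)cc2)nn1)c1cn(-c2ccccc2)nc1-c1ccccc1` is tested in a functional assay on MCF7 cells (Homo sapiens) for antiproliferative activity, read by sulforhodamine B assay, with a stated time of 48 h (on this read-out lower numbers stand for stronger inhibition of growth and higher numbers for weaker inhibition of growth), where compound 1 gives 840 nM. Compound 2 `COc1ccc(Cn2cc(CNC(=O)c3cn(-c4ccccc4)nc3-c3ccccc3)nn2)cc1` differs from it by methoxy in place of trifluoromethyl on an aromatic carbon. For compound 2 the assay reports only a limit, > 100000 nM, and this value sits at the limit of > 100000 nM in this assay, at which 1 of the 3 values shown sits. The change thus produces an at least 110-fold higher number from compound 1 to compound 2 (2.07 log units; beyond the scatter). Compound 3 `O=C(NCc1cn(Cc2ccc(C(F)(F)F)cc2)nn1)c1cn(-c2ccccc2)nc1-c1ccc(Cl)cc1` differs from compound 1 in its core by chloro in place of hydrogen on an aromatic carbon, and in this assay compound 3 gives 4900 nM, a result that amounts to a 5.8-fold higher number from compound 1 to compound 3 (0.77 log units; beyond the scatter). Compound 4 `COc1ccc(Cn2cc(CNC(=O)c3cn(-c4ccccc4)nc3-c3ccc(Cl)cc3)nn2)cc1` has not yet been measured; it differs from compound 3 by methoxy in place of trifluoromethyl on an aromatic carbon, which is the same change, at the same place, as that from compound 1 to compound 2. Beside that earlier step, the step expected from compound 3 to compound 4 is an 82-fold higher number from compound 3 to compound 4 (1.91 log units; beyond the scatter), an expectation resting on the step of an at least 110-fold higher number from compound 1 to compound 2 (2.07 log units; beyond the scatter) seen on compound 1 and on compound 3 already starting from 4900 nM. Compound 4 is therefore expected to give about 400000 nM in this assay, most likely reported only as a limit.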

Compound 4, concentration for 50% growth inhibition: 8000 nM
Compound 4: middle estimate off by 50-fold (1.70 log units), on the high side; measured number below the stated range.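

In this assay, on the core that carries chloro, methoxy in place of trifluoromethyl gives a 1.6-fold higher number from compound 3 to compound 4 (0.21 log units; within the scatter), a step far smaller than the one the same change gave on the core of compound 1, so it did not carry over: the same change on two cores in this assay, an at least 110-fold higher number (2.07 log units; beyond the scatter) from compound 1 to compound 2 and a 1.6-fold higher number (0.21 log units; within the scatter) from compound 3 to compound 4, at least 72-fold (1.86 log units) apart, beyond the scatter of two such steps

The chloro change does not carry over either, since it raised the number with trifluoromethyl in place but gives an at least 12-fold lower number from compound 2 to compound 4 (1.09 log units; beyond the scatter) with methoxy in place: the same change on two cores in this assay, a 5.8-fold higher number (0.77 log units; beyond the scatter) from compound 1 to compound 3 and an at least 12-fold lower number (1.09 log units; beyond the scatter) from compound 2 to compound 4, at least 72-fold (1.86 log units) apart, beyond the scatter of two such steps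

Compound 2 is known only through a limit, > 100000 nM, so the steps that touch it give only a minimum size, and these four compounds show that the two changes do not act independently here without showing why.

Going by these compounds, it remains open whether an amine or a simple methyl at the position of the methoxy would behave like methoxy or like trifluoromethyl on each core. On these data alone, it also remains open whether bromo or methyl in place of the chloro would produce the same reversal.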